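The source may report more compounds than this note shows. Statements on the series, on what has been measured and on what is new or still open speak of the compounds shown alone.

Measured compounds:
- compound 1 `Cc1ccc(-c2nnc(SCCOc3ccc(/C=C4\SC(=O)NC4=O)cc3)[nH]2)cc1`: 16.9%
- compound 2 `O=C1NC(=O)/C(=C/c2ccc(OCCSc3nnc(-c4ccccc4[N+](=O)[O-])[nH]3)cc2)S1`: 14.6%

Going by the values given here, in a functional assay on the whole organism (plasma, strain Wistar) with Rattus norvegicus as the target, with a stated time of 15 days, at a dose of 3 mg/kg by the oral route (on this read-out lower numbers stand for a weaker effect and higher numbers for a stronger effect at the one dose given), compound 2 gives 14.6%, and the only other number comes from compound 1 with 16.9%. The two values lie within the scatter of each other, so nothing separates them with confidence.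

Compound 3 `O=C1NC(=O)/C(=C/c2ccc(OCCSc3nnc(-c4ccc(Cl)cc4)[nH]3)cc2)S1` is not yet measured. It differs from compound 2 in one place: 4-chlorophenyl in place of 2-nitrophenyl on an aromatic carbon. Among the compounds with values here, the one step that bears on this change is the swap of one aromatic group for another on the same carbon, a number 2.3 percentage points lower from compound 1 to compound 2 (within the scatter), which stayed within the scatter. On that basis no step beyond the scatter is expected for compound 3 in this assay, and the estimated change is a number 1.4 percentage points higher from compound 2 to compound 3 (within the scatter). Compound 3 is therefore expected to give about 16%, with a range from 7% to 26%.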

Compound 3, a percentage reported as activity, at one dose (the size of the read-out at that dose, not a potency): 16%
For compound 3 middle estimate and measured number coincide at the digits printed; low and high end bracket the measured number.
By their numbers in this assay, from the lowest: compounds 2, 3 and 1 (each within the scatter of the next).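

In this assay, the exchange of 2-nitrophenyl for 4-chlorophenyl gives a number 1.4 percentage points higher from compound 2 to compound 3 (within the scatter), so the hydrogen-bond acceptors counted on 2-nitrophenyl can go, with a chlorine entering, without a step beyond the scatter. Chloro in place of methyl gives a number 0.9 percentage points lower from compound 1 to compound 3 (within the scatter), which adds a change confined to the group on the phenyl ring, and it too stays within the scatter, so all three steps among these aryl groups now read the same way. No measurement on hand explains this outcome.

The compounds shown leave open whether anything other than a substituted phenyl, such as an amine, a carboxylic acid or a longer alkyl chain, would move the number beyond the scatter at this place. With one dose given, they also leave open whether these compounds would stay together at other doses.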